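This account rests on a few compounds, and the source may have more. Where it says the series, first, only, none or still open, it means among the compounds named here.

Compound 3 `CC[C@H](C)[C@H](N)CN(C(=O)[C@@H]1C[C@H]1c1ccccc1)c1ccc(-c2ccc(OC(F)(F)F)cc2)cc1` gives 170 nM in a functional assay for agonist activity at G protein-coupled receptor 88 (Homo sapiens), read by HTRF and cAMP accumulation (a higher number here means that more compound is needed for the effect, a lower number that less compound is needed), the second highest of the three numbers in hand: compound 2 `CC[C@H](C)[C@H](N)CN(C(=O)[C@@H]1C[C@H]1c1ccccc1)c1ccc(-c2ccc(OC)cc2)cc1` gives 120 nM, and compound 1 `CC[C@H](C)[C@H](N)CN(C(=O)[C@@H]1C[C@H]1c1ccccc1)c1ccc(-c2ccc(C(C)(C)C)cc2)cc1` gives 750 nM. Compound 4 `CCOC(=O)c1ccc(-c2ccc(N(C[C@@H](N)[C@@H](C)CC)C(=O)[C@@H]3C[C@H]3c3ccccc3)cc2)cc1` differs from compound 3 by ethoxycarbonyl in place of trifluoromethoxy on an aromatic carbon. For the measured compounds named here, no measured step exchanges one substituent at this place for another of similar size; the step of a 6.3-fold lower number from compound 1 to compound 2 (0.80 log units; beyond the scatter) and the step of a 4.4-fold lower number from compound 1 to compound 3 (0.64 log units; beyond the scatter) both replace tert-butyl, while the step of a 1.4-fold higher number from compound 2 to compound 3 (0.15 log units; within the scatter) is within the scatter. On that footing compound 4 is expected to move by only a 1.2-fold higher number from compound 3 to compound 4 (0.07 log units; within the scatter), with no direction that the data can support. Compound 4 is therefore estimated at 200 nM in this assay, within a range of 80 nM to 600 nM.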

Compound 4, half-maximal effective concentration: 260 nM
Beside the measured number, compound 4's estimate is 1.3-fold (0.11 log units) below it, within the range that was stated.
By their numbers in this assay, from the lowest: compounds 2, 3 and 4 (each within the scatter of the next, the first and the last beyond it); then compound 1.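

Ethoxycarbonyl and trifluoromethoxy, with the same count of heavy atoms, cannot be told apart at this place (a 1.5-fold higher number from compound 3 to compound 4 (0.18 log units; within the scatter)). Against methoxy, ethoxycarbonyl gives the only step beyond the scatter here that does not start from tert-butyl (a 2.2-fold higher number from compound 2 to compound 4 (0.34 log units; beyond the scatter)), while it still needs less compound than tert-butyl (a 2.9-fold lower number from compound 1 to compound 4 (0.46 log units; beyond the scatter)). Nothing shown gives a cause for these steps. Still open, going by these compounds, is how a carboxylic acid, an amine or a longer alkoxy chain would read at this place in this assay, and whether a lone fluorine would match methoxy.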